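The source may hold more compounds than are shown below. What is called first, only, known or untested is meant among the compounds shown, and "the series" means these compounds.

Measured compounds:
Compound 1 `COc1cc(F)c(NC(=O)c2ccncc2)cc1Nc1nccc(-c2cn(C)c3ccccc23)n1` gives 4370 nM in a functional assay on NCI-H1975 cells (Homo sapiens) for antiproliferative activity, read by MTT assay, with a stated time of 72 h; on this read-out higher numbers stand for weaker inhibition and lower numbers for stronger inhibition.
Compound 2 `COc1cc(F)c(NC(=O)c2ccncc2OC)cc1Nc1nccc(-c2cn(C)c3ccccc23)n1` gives 4120 nM in this assay.
Compound 3 `COc1ccc(C(=O)Nc2cc(Nc3nccc(-c4cn(C)c5ccccc45)n3)c(OC)cc2F)nc1` gives 16800 nM in this assay.

Compound 3 carries the highest number of the three. The steps of a 3.8-fold higher number from compound 1 to compound 3 (0.58 log units; beyond the scatter) and a 4.1-fold higher number from compound 2 to compound 3 (0.61 log units; beyond the scatter) are both beyond the scatter, so compound 3 is the weakest inhibitor among those measured.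

Compound 4 `COc1cc(F)c(NC(=O)c2ccccn2)cc1Nc1nccc(-c2cn(C)c3ccccc23)n1` is not yet measured. It differs from compound 3 by hydrogen in place of methoxy on an aromatic carbon.

Within the data shown here, the only measured step that touches a methoxy on the amide pyridine is a 1.1-fold lower number from compound 1 to compound 2 (0.03 log units; within the scatter), which lies within the scatter. That methoxy sat on a pyridin-4-yl, giving 3-methoxypyridin-4-yl, whereas compound 3 carries 5-methoxypyridin-2-yl, so it is an imperfect guide. The steps of a 3.8-fold higher number from compound 1 to compound 3 (0.58 log units; beyond the scatter) and a 4.1-fold higher number from compound 2 to compound 3 (0.61 log units; beyond the scatter) alter the pyridyl attachment itself, which compound 4 keeps from compound 3, so they do not bear directly on the present change. The expected step of a 1.2-fold lower number from compound 3 to compound 4 (0.08 log units; within the scatter) is therefore small and not beyond the scatter, with the number staying near that of compound 3.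

For compound 4 the estimate in this assay is 14000 nM, within a range from 6000 nM to 35000 nM.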

Compound 4, half-maximal inhibitory concentration: 16500 nM
Compound 4: the middle estimate sits 1.2-fold (0.07 log units) below what was measured; the measured number falls inside the stated range.
By their numbers in this assay, from the lowest: compounds 2 and 1 (each within the scatter of the next); then compounds 4 and 3 (each within the scatter of the next).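

Removing the methoxy from the 5-methoxypyridin-2-yl amide leaves the number in this assay unmoved, a 1.0-fold lower number from compound 3 to compound 4 (0.01 log units; within the scatter), so at this position, two atoms from the ring nitrogen, the read-out does not separate methoxy from hydrogen. Among these compounds, the methoxy-for-hydrogen swap, until now seen only on the pyridin-4-yl amide, thus stays silent on the pyridin-2-yl amide as well: the same change on two cores in this assay, a 1.1-fold lower number (0.03 log units; within the scatter) from compound 1 to compound 2 and a 1.0-fold higher number (0.01 log units; within the scatter) from compound 4 to compound 3, 1.1-fold (0.03 log units) apart, within the scatter of two such steps. With no methoxy present on either side, the pyridin-2-yl amide still gives a 3.8-fold higher number from compound 1 to compound 4 (0.58 log units; beyond the scatter), and against the 3-methoxypyridin-4-yl amide it gives a 4.0-fold higher number from compound 2 to compound 4 (0.60 log units; beyond the scatter), so the weaker inhibition of compound 3 goes with the pyridin-2-yl attachment and not with its methoxy.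

Going by these compounds, only hydrogen and methoxy are seen at this position, so whether a dimethylamino group or a carboxylic acid there would shift the number remains open. Also open, on these data alone, is whether a pyridin-3-yl on the carbonyl would fall with the pyridin-4-yl compounds or with the pyridin-2-yl compounds.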